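Ethyl in place of hydrogen: notes on the series

This account rests on a few compounds, and the source may have more. Where it says the series, first, only, none or still open, it means among the compounds named here.

Values so far in a functional assay on MCF7 cells (Homo sapiens) for cytotoxicity, read by MTT assay, with a stated time of 48 h (a lower number here means a stronger inhibitor of growth, a higher number a weaker inhibitor of growth), for the measured compounds:
compound 1 `CC(C)n1c(C(F)(F)F)nc2cc(Cl)c(Cl)cc21` gives 70500 nM
compound 2 `Clc1cc2ncn(C3CCCC3)c2cc1Cl` gives 42000 nM

Compound 2 at 42000 nM lies within the usual scatter of compound 1 at 70500 nM in this series, so the two values cannot be told apart. The next compound to be tested is compound 3 `CCc1nc2cc(Cl)c(Cl)cc2n1C1CCCC1`, which has ethyl in place of hydrogen on an aromatic carbon of compound 2. The counted change is ethyl in place of hydrogen on an aromatic carbon and nothing else differs.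

For the measured compounds named here, no measured pair isolates a change in one place, so the data give no direction for this substitution. In this assay no step beyond the scatter is expected, and the expectation starts from compound 2 at 42000 nM as its anchor. The estimated move is a 1.2-fold lower number from compound 2 to compound 3 (0.08 log units; within the scatter) and it is expected to stay within the scatter. For compound 3 the expected value is 35000 nM, with an estimated range from 12000 nM to 90000 nM in this test.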

Compound 3, concentration for 50% growth inhibition: 52000 nM
Compound 3: the middle estimate sits 1.5-fold (0.17 log units) below what was measured, within the range that was stated.
By their numbers in this assay, from the lowest: compounds 2, 3 and 1 (each within the scatter of the next).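

In this assay, the first single-place change available in the series gives a 1.2-fold higher number from compound 2 to compound 3 (0.09 log units; within the scatter). Ethyl in place of hydrogen on this aromatic carbon, between two ring nitrogen atoms and next to the ring atom that bears a cyclopentyl group, therefore leaves the read-out within the scatter, a reading that compounds 1 and 2 could not give because they differ in more than one place. No measurement at hand offers an explanation of this result.

As far as these compounds go, how an amine, a carboxylic acid or a longer chain such as butyl on this same carbon would read stays open, so the hydrogen and ethyl pair does not show whether any change at this position can produce a step beyond the scatter. Also open, from the compounds shown here alone, is whether the ethyl result would carry over to a core with isopropyl in place of cyclopentyl, and compound 1, which has trifluoromethyl on this carbon and also differs in that other group, cannot settle the point.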